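Swapping the amide substituent on a vitamin D receptor agonist

The source may report more compounds than this note shows. Statements on the series, on what has been measured and on what is new or still open speak of the compounds shown alone.

Measured so far:
compound 1, `CCn1c(C(=O)Nc2cccc(C(F)(F)F)c2)ccc1C(CC)(CC)c1ccc(OCCC(O)(CC)CC)c(C)c1`, 5900 nM
compound 2, `CCn1c(C(=O)NC(C)C(=O)O)ccc1C(CC)(CC)c1ccc(OCCC(O)(CC)CC)c(C)c1`, 66 nM

In an assay on cells for agonist activity at vitamin D3 receptor (Homo sapiens), with a stated time of 96 h (on this read-out lower numbers stand for an effect already at smaller amounts and higher numbers for an effect only at larger amounts of compound), compound 2 gives the lower of the two numbers shown, and its only neighbour is compound 1. Among the measured compounds shown here, the one step in hand is an 89-fold lower number from compound 1 to compound 2 (1.95 log units; beyond the scatter), a large move in the direction of an effect at smaller amounts.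

Compound 3, `CCn1c(C(=O)N(C)CCO)ccc1C(CC)(CC)c1ccc(OCCC(O)(CC)CC)c(C)c1`, has not yet been measured in this assay. It differs from compound 2 in one place: (2-hydroxyethyl)(methyl)amino in place of (1-carboxyethyl)amino on a carbonyl carbon. The group that leaves is the one whose arrival produced the large step from compound 1 to compound 2, and the group that enters is neither the 1-carboxyethyl of compound 2 nor the 3-(trifluoromethyl)phenyl of compound 1. The measured step bears on this change only indirectly, so the expectation is a move back toward the number of compound 1, but smaller than the full gap. The expected step is a 12-fold higher number from compound 2 to compound 3 (1.08 log units; beyond the scatter), and compound 3 is estimated at 800 nM, with a range from 150 nM to 4500 nM.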

Compound 3, half-maximal effective concentration: 52.7 nM
Compound 3: middle estimate off by 15-fold (1.18 log units), on the high side, outside the stated range (below it).
By their numbers in this assay, from the lowest: compounds 3 and 2 (each within the scatter of the next); then compound 1.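

In this assay, two quite different amino groups on this carbonyl carbon give numbers that cannot be told apart, with a 1.3-fold lower number from compound 2 to compound 3 (0.10 log units; within the scatter). A low number in this series therefore requires neither the carboxylic acid of the 1-carboxyethyl group nor a hydrogen on the amide nitrogen, since compound 3 has neither of these features. The large gap seen earlier also appears with a second group, at a 110-fold lower number from compound 1 to compound 3 (2.05 log units; beyond the scatter), so among these three compounds it is the 3-(trifluoromethyl)phenyl of compound 1 that stands apart, rather than the 1-carboxyethyl of compound 2 being special.

There is no measurement here that explains how these groups produce these numbers. The compounds shown leave open which part of (2-hydroxyethyl)(methyl)amino matters, and whether the hydroxyl is needed at all, a question that a dimethylamino group on the same carbonyl carbon, or a longer chain such as 3-hydroxypropyl in place of the 2-hydroxyethyl, would address.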